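The compounds below may be only part of what the source reports. "The series", "measured", "known", "first", "only" and "open" are said of these compounds alone.

Measured so far in a functional assay on HL-60 cells (Homo sapiens) for antiproliferative activity, read by MTT assay, with a stated time of 24 h (on this read-out higher numbers stand for weaker inhibition and lower numbers for stronger inhibition), are these compounds:

compound 1 `CCCCc1oc2ccccc2c1C(=O)c1ccc(OCC(N)=O)cc1` gives > 50000 nM
compound 2 `CCCCc1oc2ccccc2c1C(=O)c1ccc(OCCCC(=O)N[C@@H](C)c2ccccc2)cc1` gives > 50000 nM
compound 3 `CCCCc1oc2ccccc2c1C(=O)c1cc(I)c(OCCCN2CCN(C)CC2)c(I)c1` gives > 50000 nM

Each of these entries is a limit of the assay and not a number. In this assay compound 3 gives > 50000 nM as such a limit. The whole set stands together, with the limit of > 50000 nM in this assay, at which 3 of the 3 values shown sit, and no number by which to rank the compounds.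

The step to compound 4 `CCCCc1oc2ccccc2c1C(=O)c1cc(I)c(OCCCNCc2ccccc2)c(I)c1` is benzylamino in place of 4-methylpiperazin-1-yl on a saturated chain carbon, three bonds along the chain from an oxygen on an aromatic ring and it falls on a saturated chain carbon, three bonds along the chain from an oxygen on an aromatic ring. Benzylamino stands there in place of 4-methylpiperazin-1-yl.

Going by the values given here, no step between measured compounds that differ in one place is available to scale this change. With compound 3 held at > 50000 nM as a limit, only a modest shift toward stronger inhibition is expected, or none beyond the scatter, and a further limit is quite possible. The expected size is an at least 1.1-fold lower number from compound 3 to compound 4 (0.04 log units; that floor lies within the scatter) in this assay and it remains an estimate. The estimated value for compound 4 is 45000 nM with an expected range of 15000 nM to 90000 nM on this read-out.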

Compound 4, half-maximal inhibitory concentration: 4400 nM
Compound 4: middle estimate off by 10-fold (1.01 log units), on the high side; measured number outside the range, below it.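

In this assay, benzylamino in place of 4-methylpiperazin-1-yl on a saturated chain carbon, three bonds along the chain from an oxygen on an aromatic ring, gives an at least 11-fold lower number from compound 3 to compound 4 (1.05 log units; beyond the scatter), so the group at this place can move the read-out to a measurable level. Compound 3 gives > 50000 nM, which is a limit and not a number, so the step has a floor and no upper bound. Compound 4 is the only compound shown with a number, while the others all sit at one limit: the limit of > 50000 nM in this assay, at which 3 of the 4 values shown sit.

The compounds shown leave open whether the aromatic ring of benzylamino or its amine hydrogen goes with the step, which a dimethylamino group or a piperidine ring at the same place would help to separate. They also leave open how the benzylamino step reads on a longer chain.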